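Swapping Cyclohexyl for 4-Methylphenyl on a Ring Nitrogen

The source may hold more compounds than are shown below. What is called first, only, known or untested is meant among the compounds shown, and "the series" means these compounds.

Compound 1 `O=C1COc2ccc(-c3cnc(Cl)c(NS(=O)(=O)c4ccc(F)cc4)c3)cc2N1C1CCCCC1` and compound 3 `O=C1COc2ccc(-c3cccc(NS(=O)(=O)c4ccc(F)cc4)c3)cc2N1C1CCCCC1` both carry a cyclohexyl group on an amide-type nitrogen in a ring, but their cores are not the same; the difference between the two cores is not broken down here. In a functional assay on MCF7 cells (Homo sapiens) for antiproliferative activity, read by MTT assay, with a stated time of 72 h (on this read-out higher numbers stand for weaker inhibition and lower numbers for stronger inhibition), compound 1 gives > 40000 nM, and this is a limit of the assay rather than a number. In this assay compound 3 gives 21400 nM.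

Compound 2 `Cc1ccc(N2C(=O)COc3ccc(-c4cnc(Cl)c(NS(=O)(=O)c5ccc(F)cc5)c4)cc32)cc1` differs from compound 1 in one place only, (4-methylphenyl in place of cyclohexyl on an amide-type nitrogen in a ring). In this assay compound 2 gives 32600 nM. The step itself is an at least 1.2-fold lower number from compound 1 to compound 2 (0.08 log units; that floor lies within the scatter), and only a floor for it is known because the value of compound 1 sits at the limit of > 40000 nM in this assay, at which 1 of the 3 values shown sits. The two values therefore show a pair that cannot be told apart with confidence, not a clear improvement.

Compound 4 `Cc1ccc(N2C(=O)COc3ccc(-c4cccc(NS(=O)(=O)c5ccc(F)cc5)c4)cc32)cc1` has not yet been measured. It differs from compound 3 by the same change, (4-methylphenyl in place of cyclohexyl on an amide-type nitrogen in a ring), made at the same place of the same kind of ring. The step from compound 3 to compound 4 is expected to be a 1.3-fold lower number from compound 3 to compound 4 (0.10 log units; within the scatter), an expectation that rests on the measured step of an at least 1.2-fold lower number from compound 1 to compound 2 (0.08 log units; that floor lies within the scatter), which gave no more than a small shift. Compound 4 is therefore expected to give about 17000 nM in this assay. The estimate for compound 4 is expected to fall in the range from 7000 nM to 40000 nM.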

Compound 4, half-maximal inhibitory concentration: 32100 nM
Estimate against measurement, compound 4: 1.9-fold (0.28 log units) below; the measured number falls inside the stated range.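

In this assay, putting 4-methylphenyl in place of cyclohexyl on the core of compound 3 gives a 1.5-fold higher number from compound 3 to compound 4 (0.18 log units; within the scatter), so this pair cannot be told apart with confidence, and the core of compound 3 offers no clear effect of the change that could be compared with another core. Set beside the earlier step, the same change on the two cores reads as follows: the same change on two cores in this assay, an at least 1.2-fold lower number (0.08 log units; that floor lies within the scatter) from compound 1 to compound 2 and a 1.5-fold higher number (0.18 log units; within the scatter) from compound 3 to compound 4; the limit leaves it open whether they differ. This does not show that the change has the same size on both cores, or that it does nothing on the core of compound 1, since only a floor is known for the step on that core: the limit of > 40000 nM in this assay, at which 1 of the 4 values shown sits.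

The compounds shown leave open whether a group of a different kind on the amide-type nitrogen, such as a chain ending in an amine or in a carboxylic acid, would give a step beyond the usual scatter in this assay. Among these compounds, with only cyclohexyl and 4-methylphenyl at this place and only two cores to compare, it also remains open how this change would behave on any further core.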